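The source may report more compounds than this note shows. Statements on the series, on what has been measured and on what is new or still open speak of the compounds shown alone.

Working notes on the series in a functional assay (MiaPaCa cells, Homo sapiens) for inhibition, read by sulforhodamine B assay, with a stated time of 48 h; a higher number here means a weaker inhibitor of growth, a lower number a stronger inhibitor of growth.

Among the compounds with values here, compound 1 `O=C(CCN1C(=O)CSc2ccccc21)N1CCN(c2ccc(C(F)(F)F)cc2)CC1` is the first measured member. In this assay compound 1 gives > 100000 nM, which is a limit of the assay and not a number. Compound 2 `O=C(CCN1C(=O)CSc2ccccc21)N1CCN(c2ccccc2F)CC1` differs from compound 1 by 2-fluorophenyl in place of 4-(trifluoromethyl)phenyl on an amine nitrogen in a ring. In this assay compound 2 gives > 100000 nM, again a limit. The step that the two limits leave unreadable from compound 1 to compound 2 is therefore unreadable in size, since both ends sit at a limit.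

Compound 3 `O=C(CCN1C(=O)CSc2ccccc21)NCCCN1CCN(c2ccc(C(F)(F)F)cc2)CC1` carries the same 4-(trifluoromethyl)phenyl group as compound 1 on a different core; the difference between the two cores is not broken down here. In this assay compound 3 gives > 100000 nM, once more a limit. The whole measured set is summarised by the limit of > 100000 nM in this assay, at which 3 of the 3 values shown sit.

Compound 4 `O=C(CCN1C(=O)CSc2ccccc21)NCCCN1CCN(c2ccccc2F)CC1` has not yet been measured. It differs from compound 3 by 2-fluorophenyl in place of 4-(trifluoromethyl)phenyl on an amine nitrogen in a ring, with the place of the change described in the same words as for the pair of compound 1 and compound 2, so the change is the same one made a second time. Within the data shown here, because the limit of > 100000 nM in this assay, at which 3 of the 3 values shown sit, leaves the first occurrence of this change without a readable size, the step that the limit leaves unreadable from compound 3 to compound 4 is expected to be small, with compound 4 expected to remain at the limit. For compound 4 the expected value is 150000 nM, with the range running from 60000 nM to 400000 nM.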

Compound 4, concentration for 50% growth inhibition: > 100000 nM
Compound 4: only a limit was reported; the forecaster's own chance of this, stated with the estimate: 85%; the middle value does not contradict the limit.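

In this assay compound 4 gives > 100000 nM, a limit of the assay and not a number. Compound 3 also sits at a limit, so no size can be read for the change between compound 3 and compound 4, and the whole set stays at one value: the limit of > 100000 nM in this assay, at which 4 of the 4 values shown sit. The compounds shown leave open whether any member of the series gives a readable value, and how 2-fluorophenyl and 4-(trifluoromethyl)phenyl compare.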